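Furan for methoxyphenyl on the chalcone arm of compound 3

The compounds below may be only part of what the source reports. "The series", "measured", "known", "first", "only" and "open" are said of these compounds alone.

Measured so far:
compound 1 `O=C(CO[N+](=O)[O-])Nc1ccc(C(=O)/C=C/c2ccco2)cc1`, 48%
compound 2 `CC(=O)c1ccc(OCC(=O)Nc2ccc(C(=O)/C=C/c3ccco3)cc2)cc1`, 45%
compound 3 `COc1ccc(/C=C/C(=O)c2ccc(NC(=O)COc3ccc(/C(C)=N\O)cc3)cc2)cc1`, 46%

In a functional assay on the whole organism (strain albino) for inhibition, with Rattus norvegicus as the target, read by paw edema, with stated times of 30 min and 3 h, at a dose of 100 mg/kg by the oral route (a lower number here means less inhibition, a higher number more inhibition at the dose given (going by the name of the read-out)), compound 1 gives 48%, compound 2 gives 45%, and compound 3 gives 46%. The number of compound 3 is the second highest of the three, yet it lies within the scatter of both compound 2 and compound 1. Within the data shown here, the only measured step, a number 3 percentage points lower from compound 1 to compound 2 (within the scatter), changes a different part of the molecule and stays within the scatter.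

Compound 4 `C/C(=N/O)c1ccc(OCC(=O)Nc2ccc(C(=O)/C=C/c3ccco3)cc2)cc1` differs from compound 3 as follows: furan-2-yl in place of 4-methoxyphenyl on a double-bonded chain carbon bound to a double-bonded chain carbon. Among the measured compounds shown here, no measured step concerns this change, so only the narrow spread of the three numbers guides the expectation. Compound 4 is therefore expected to show no change at the digits printed from compound 3 to compound 4 (within the scatter), nothing beyond the scatter, with an estimated value of 46% between 36% and 56%.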

Compound 4, a percentage reported as inhibition, in the whole organism at one dose (the size of the read-out at that dose, not a potency): 49%
Estimate against measurement, compound 4: 3 percentage points below; measured number inside the range.
By their numbers in this assay, from the lowest: compounds 2, 3, 1 and 4 (each within the scatter of the next).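

In this assay, furan-2-yl in place of 4-methoxyphenyl on a double-bonded chain carbon bound to a double-bonded chain carbon gives a number 3 percentage points higher from compound 3 to compound 4 (within the scatter) and so shows that either ring can stand at this position without a step beyond the scatter. With furan-2-yl in place, the far end also gives only a number 4 percentage points higher from compound 2 to compound 4 (within the scatter) for the change on an aromatic carbon and a number 1 percentage points higher from compound 1 to compound 4 (within the scatter) for the change on an oxygen on a saturated carbon. Nothing available explains these numbers.

On these data alone, whether an amine or a carboxylic acid at this position would give a step beyond the scatter remains open.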